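This account rests on a few compounds, and the source may have more. Where it says the series, first, only, none or still open, it means among the compounds named here.

Compound 1 `C=CC1=C(C(=O)NCc2ccc(C)cc2)C(c2ccc(OC)cc2)OC1` in a functional assay on A549 cells (Homo sapiens) for cytotoxicity, read by MTT assay, with a stated time of 24 h (a lower number here means a stronger inhibitor, a higher number a weaker inhibitor), gives > 100000 nM, a limit of the assay rather than a number.
Compound 2 `C=CC1=C(C(=O)NCc2ccc(C)cc2)C(c2ccc(F)cc2)OC1` in this assay gives > 100000 nM, likewise a limit rather than a number.

Among the compounds with values here, compound 2 thus stands at the edge of what this assay reports, with no number of its own; the only other value shown sits at the same limit, as the limit of > 100000 nM in this assay, at which 2 of the 2 values shown sit, records. The step from compound 1 to compound 2, a step that the two limits leave unreadable from compound 1 to compound 2, is therefore of a size that the two limits leave unreadable, and the change there was a fluoro in place of methoxy on an aromatic carbon, which is a different place from the one now altered.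

Compound 3 `C=CC1=C(C(=O)NC2CCCCC2)C(c2ccc(F)cc2)OC1` is not yet measured. It differs from compound 2 by cyclohexyl in place of 4-methylbenzyl on an amide-type nitrogen. No measured step touches the amide nitrogen, so nothing shown speaks directly to this change in either direction. With both measured values resting at the limit, the expectation for compound 3 in this assay is that it will most likely also reach only a limit, and the step from compound 2 to compound 3 is estimated as a number no higher from compound 2 to compound 3 (the limit leaves the size open), none beyond the scatter. Compound 3 is accordingly estimated at 100000 nM, within a range from 40000 nM to 300000 nM.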

Compound 3, half-maximal inhibitory concentration: > 100000 nM
Compound 3: only a limit was reported (the forecaster's own chance of this, stated with the estimate: 80%); the middle value sits exactly at the limit.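

In this assay compound 3 gives > 100000 nM, a limit rather than a number, so its step from compound 2 cannot be read. All three compounds now rest at the same point: the limit of > 100000 nM in this assay, at which 3 of the 3 values shown sit.

The compounds shown leave open whether cyclohexyl and 4-methylbenzyl on the amide-type nitrogen differ at all in this assay, since no number lies within its reported range.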